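From carboxymethyl to 2-carboxyethyl on the shared core

The source may report more compounds than this note shows. Statements on the series, on what has been measured and on what is new or still open speak of the compounds shown alone.

In a functional assay on MKN-45 cells (Homo sapiens) for inhibition, with a stated time of 72 h (on this read-out lower numbers stand for stronger inhibition and higher numbers for weaker inhibition), compound 1 (`COc1cc(C(=O)c2ccc3c(ccn3C(C)C)c2)cc(OC)c1OC`) gives (470 nM) and compound 2 (`COc1cc(C(=O)c2ccc3c(ccn3CC(=O)O)c2)cc(OC)c1OC`) gives (396 nM). Among the measured compounds shown here, these are the only two numbers so far, and they lie within the scatter of each other, so compound 2 cannot be told apart from compound 1.

Compound 3 (`COc1cc(C(=O)c2ccc3c(ccn3CCC(=O)O)c2)cc(OC)c1OC`) differs from compound 2 by a single change (carboxymethyl in place of carboxy on a saturated chain carbon bound to an aromatic nitrogen): carboxymethyl in place of carboxy on a saturated chain carbon bound to an aromatic nitrogen, which also reads as carboxymethyl to 2-carboxyethyl.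

For the measured compounds named here, one measured step bears on this place (a 1.2-fold lower number from compound 1 to compound 2 (0.07 log units; within the scatter)): carboxymethyl in place of isopropyl on an aromatic nitrogen, a step within the scatter. Going by the values given here, it is small, but it is only one step, and no measured pair varies the chain while keeping the carboxy end. On that single step, no change beyond the scatter is expected in this assay (a 1.0-fold higher number from compound 2 to compound 3 (0.00 log units; within the scatter)). The estimate for compound 3 is (400 nM), with an expected range from (160 nM) to (1000 nM).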

Compound 3, half-maximal inhibitory concentration: > 10000 nM
Compound 3: only a limit was reported; the forecaster's own chance of this, stated with the estimate: 3%; middle value at least 25-fold (1.39 log units) away from the limit.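

In this assay, the saturated chain carbon bound to an aromatic nitrogen proves sensitive to a change of a single added carbon: going from carboxymethyl to 2-carboxyethyl gives an at least 25-fold higher number from compound 2 to compound 3 (1.40 log units; beyond the scatter), whereas the earlier exchange of isopropyl for carboxymethyl stayed within the scatter. Measured against isopropyl on the same nitrogen the loss is just as clear, an at least 21-fold higher number from compound 1 to compound 3 (1.32 log units; beyond the scatter), so across these three compounds the substituent on this nitrogen is not freely interchangeable, as the first pair alone might have suggested. For compound 3 the reported > 10000 nM is a limit and not a number: the limit of > 10000 nM in this assay, at which 1 of the 3 values shown sits.

Open, going by these compounds, is whether the loss follows from the longer chain itself or from the carboxylic acid at its end, and a plain propyl chain or a primary amide at the chain end on the shared core would separate the two. Also open, on these data alone, is whether a still longer chain ending in a carboxylic acid stays as weak as compound 3, or whether a methyl ester of 2-carboxyethyl behaves differently.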